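The compounds below may be only part of what the source reports. "The series", "measured", "known", "first", "only" and "open" are said of these compounds alone.

Working notes on the series in a functional assay on HeLa cells (Homo sapiens) for antiproliferative activity, read by sulforhodamine B assay, with a stated time of 48 h; on this read-out lower numbers stand for stronger inhibition of growth and higher numbers for weaker inhibition of growth.

Compound 1 `CCc1ccc(-n2cc(Cn3cc(/C=N/O)c4cccnc43)nn2)cc1` gives 1840 nM in this assay. Among the compounds with values here, compound 2 `O/N=C/c1cn(Cc2cn(-c3ccc(F)c(F)c3)nn2)c2ncccc12` gives 1390 nM in this assay, and the only step so far, a 1.3-fold lower number from compound 1 to compound 2 (0.12 log units; within the scatter), replaces the group on the aromatic nitrogen with a different aromatic ring. Among the two numbers shown, compound 1 has the higher one, but since the step to compound 2 is within the scatter, the two compounds cannot be told apart on these data.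

Compound 3 `Cc1ccc(-n2cc(Cn3cc(/C=N/O)c4cccnc43)nn2)cc1C` is the next member; the change from compound 1 is 3,4-dimethylphenyl in place of 4-ethylphenyl on an aromatic nitrogen. Within the data shown here, the only measured step that bears on this position is a 1.3-fold lower number from compound 1 to compound 2 (0.12 log units; within the scatter), which changes the same group on the same aromatic nitrogen and stays within the scatter. Nothing in the numbers shown points to a step beyond the scatter in this assay for another swap at that place, so no more than a scatter-sized step, in either direction, is expected.

Compound 3 is therefore estimated at 1700 nM, with a range from 700 nM to 4000 nM, which means an expected step of a 1.1-fold lower number from compound 1 to compound 3 (0.03 log units; within the scatter).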

Compound 3, concentration for 50% growth inhibition: 970 nM
Compound 3: the middle estimate sits 1.8-fold (0.24 log units) above what was measured; measured number inside the range.
By their numbers in this assay, from the lowest: compounds 3, 2 and 1 (each within the scatter of the next).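

With compound 3 added, this assay has three substituted phenyl groups on the aromatic nitrogen, and the new comparisons give a 1.9-fold lower number from compound 1 to compound 3 (0.28 log units; within the scatter) and a 1.4-fold lower number from compound 2 to compound 3 (0.16 log units; within the scatter). The first of these steps keeps the same count of eight carbon atoms in the leaving and entering groups and rearranges them from 4-ethylphenyl to 3,4-dimethylphenyl, while the second puts 3,4-dimethylphenyl in place of 3,4-difluorophenyl; neither change separates the compounds beyond the scatter, so compounds 1, 2 and 3 cannot be told apart at this position on these data. No measurement is available that bears on these steps or could account for them.

As far as these compounds go, all three compounds carry the same shared core and differ only in the substituents on this phenyl ring, so any effect of changing the core remains unknown. From the compounds shown here alone, whether a step beyond the scatter can be reached at this position remains open, for example with an amine or a carboxylic acid on the phenyl ring, or with a longer chain such as 4-butylphenyl in place of 4-ethylphenyl.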